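The source may report more compounds than this note shows. Statements on the series, on what has been measured and on what is new or still open speak of the compounds shown alone.

Working notes on the series. For the measured compounds named here, compound 2 `CN1CCN(CCCOc2cccc3nc(Nc4ccc(F)c(F)c4)ccc23)CC1` gives 21100 nM in a functional assay on cells (Panel leukemia (Carcinoma cell lines), Homo sapiens) for inhibition, read by sulforhodamine B assay, with a stated time of 48 h (a lower number here means that less compound is tolerated, a higher number that more compound is tolerated), the highest of the two numbers measured so far. Going by the values given here, the nearest point is compound 1 `CN1CCN(CCCOc2cccc3nc(Nc4ccc(Cl)c(C(F)(F)F)c4)ccc23)CC1`, which in this assay gives 7780 nM; the single measured step, a 2.7-fold higher number from compound 1 to compound 2 (0.43 log units; beyond the scatter), exchanges only the phenyl group on the nitrogen on the aromatic ring and is the sole comparison available. Compound 3 `CN1CCN(CCCOc2cccc3nc(Nc4cc(Cl)cc(Cl)c4)ccc23)CC1` is not yet measured. It differs from compound 2 by 3,5-dichlorophenyl in place of 3,4-difluorophenyl on a nitrogen on an aromatic ring. This change again touches only the phenyl group on that nitrogen, so the step from compound 1 to compound 2 bears on it directly; that step was modest and ran towards a higher number when the two fluorines replaced the chlorine and trifluoromethyl. With chlorines entering in place of fluorines, the step to compound 3 is expected to be a 1.8-fold lower number from compound 2 to compound 3 (0.25 log units; within the scatter), of uncertain size. For compound 3 the estimate in this assay is 12000 nM, expected to fall between 5000 nM and 30000 nM.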

Compound 3, concentration lethal to 50% of the cells: 100000 nM
Beside the measured number, compound 3's estimate is 8.3-fold (0.92 log units) below it; the measured number lies above the stated range.
By their numbers in this assay, from the lowest: compound 1; then compound 2; then compound 3.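

In this assay, the phenyl group on the nitrogen on an aromatic ring proves able to shift the number much further than the first step indicated, with a 4.7-fold higher number from compound 2 to compound 3 (0.68 log units; beyond the scatter) and a 13-fold higher number from compound 1 to compound 3 (1.11 log units; beyond the scatter). Chlorine as such does not set the direction: compound 3 with 3,5-dichlorophenyl gives the highest number of the three, while compound 1, whose 4-chloro-3-(trifluoromethyl)phenyl also carries chlorine, gives the lowest. No supporting data on the origin of these steps are at hand.

The step to compound 3 exchanges the halogen and its placement together, and 3,4-dichlorophenyl or 3,5-difluorophenyl on the same nitrogen would separate the two. On these data alone, how a phenyl group with no halogen, or one bearing methoxy, would read also remains open.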